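Removing the ring hydroxy from a nitrile-bearing urea

This account rests on a few compounds, and the source may have more. Where it says the series, first, only, none or still open, it means among the compounds named here.

Measured compounds:
compound 1, `CC1(C)Oc2cc(-c3ncco3)c(-c3ncco3)cc2[C@@H](NC(=O)Nc2ccccc2)[C@@H]1O`, 1400 nM
compound 2, `CC1(C)Oc2ccc(C#N)cc2[C@@H](NC(=O)Nc2ccccc2)[C@H]1O`, 6200 nM

In a functional assay (aorta) for inhibition, with Rattus norvegicus as the target (a lower number here means a stronger inhibitor, a higher number a weaker inhibitor), compound 1 gives 1400 nM. In this assay compound 2 gives 6200 nM, the highest of the two numbers, and the gap to compound 1 lies beyond the scatter, so compound 2 is the weaker inhibitor of the pair.

Compound 3, `CC1(C)C[C@H](NC(=O)Nc2ccccc2)c2cc(C#N)ccc2O1`, has not yet been measured in this assay. It differs from compound 2 by hydrogen in place of hydroxy on a saturated ring carbon of the six-membered non-aromatic ring. Among the measured compounds shown here, no measured pair shows such a change here, so its effect cannot be read from the data. The expectation is that compound 3 is a weaker inhibitor than compound 2, with a step of a 2.4-fold higher number from compound 2 to compound 3 (0.38 log units; beyond the scatter). Compound 3 is estimated at 15000 nM, within a range of 4000 nM to 60000 nM.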

Compound 3, half-maximal inhibitory concentration: 1800 nM
Estimate against measurement, compound 3: 8.3-fold (0.92 log units) above; the whole stated range lies above it.
By their numbers in this assay, from the lowest: compounds 1 and 3 (each within the scatter of the next); then compound 2.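

In this assay the exchange of hydroxy for hydrogen on this saturated ring carbon gives a 3.4-fold lower number from compound 2 to compound 3 (0.54 log units; beyond the scatter) and so a stronger inhibitor, a modest step that still lies beyond the scatter. For this nitrile-bearing urea, then, the hydroxy is not required for activity, and the compound does better without it. Nothing available accounts for the change, which can only be recorded here as an observation.

This one pair cannot say whether the same exchange would have a similar effect on the core of compound 1, which carries two oxazole-type rings in place of the nitrile. It also leaves open how other groups on this carbon, such as an amine, a methoxy group or a fluorine atom, would compare with hydrogen and hydroxy.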